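Methyl at the carbamate carbon: one carbon added to compound 2

The compounds below may be only part of what the source reports. "The series", "measured", "known", "first", "only" and "open" are said of these compounds alone.

Compound 1 `CCC(COc1cccc(C(F)(F)F)c1)OC(=O)NCc1ccccc1`: > 100000 nM
Compound 2 `O=C(NCc1ccccc1)OCCOc1cccc(C(F)(F)F)c1`: > 100000 nM

Compound 1 `CCC(COc1cccc(C(F)(F)F)c1)OC(=O)NCc1ccccc1` is measured in an assay for inhibition of zeta-carotene desaturase, chloroplastic/chromoplastic (Capsicum annuum), using a Dixon plot, with a stated time of 8 h (a lower number here means a stronger inhibitor, a higher number a weaker inhibitor), and gives only a limit of the assay, > 100000 nM. Compound 2 `O=C(NCc1ccccc1)OCCOc1cccc(C(F)(F)F)c1` in this assay likewise gives only a limit, > 100000 nM. Among the measured compounds shown here, the one measured step, a step that the two limits leave unreadable from compound 1 to compound 2, is therefore unreadable in size, because of the limit of > 100000 nM in this assay, at which 2 of the 2 values shown sit. Compound 2 thus stands at the limit, with no number of its own.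

Compound 3 `CC(COc1cccc(C(F)(F)F)c1)OC(=O)NCc1ccccc1` differs from compound 2 by methyl in place of hydrogen on a saturated chain carbon bound to an oxygen next to a carbonyl group and a saturated chain carbon. For the measured compounds named here, the only step bearing on this change is the unreadable one from compound 1 to compound 2; the step from compound 2 to compound 3 in this assay is expected to be a step that the limit leaves unreadable from compound 2 to compound 3, no change beyond the scatter. For compound 3 the value in this assay is estimated at 200000 nM, within 100000 nM to 1000000 nM, most probably reported again only as a limit.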

Compound 3, half-maximal inhibitory concentration: > 100000 nM
Compound 3: a limit, no number; the forecaster's own chance of this, stated with the estimate: 90%; the middle value lies beyond the limit too.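

In this assay, among the compounds shown here, compound 3 gives only a limit, > 100000 nM, so no step among compound 1, compound 2 and compound 3 can be read. The compounds shown leave open whether hydrogen, methyl or ethyl at this carbon makes any difference to inhibition.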